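Compound 1 and the 3-hydroxyphenyl question

This account rests on a few compounds, and the source may have more. Where it says the series, first, only, none or still open, it means among the compounds named here.

Values in a functional assay on MGC-803 cells (Homo sapiens) for inhibition, read by MTT assay, with a stated time of 72 h (a lower number here means a stronger inhibitor, a higher number a weaker inhibitor), for the measured compounds
- compound 1 `C#CCSc1nc(Nc2ccccc2Cl)c2ccncc2n1` gives 27600 nM
- compound 2 `C#CCSc1nc(Nc2ccc(Cl)cc2Cl)c2ccncc2n1` gives 25500 nM
- compound 3 `C#CCSc1nc(Nc2ccccc2OC)c2ccncc2n1` gives 3440 nM

Compound 1 sits at the weak end of these three numbers. Chloro in place of hydrogen on an aromatic carbon gives a 1.1-fold lower number from compound 1 to compound 2 (0.03 log units; within the scatter) and so shows no readable change. Methoxy in place of chloro on an aromatic carbon gives an 8.0-fold lower number from compound 1 to compound 3 (0.90 log units; beyond the scatter) and is the only measured step that clears the scatter.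

Compound 4 `C#CCSc1nc(Nc2cccc(O)c2)c2ccncc2n1` has not been measured. Its difference from compound 1 is 3-hydroxyphenyl in place of 2-chlorophenyl on a nitrogen on an aromatic ring and this removes the chloro along with the whole 2-chlorophenyl. Compound 2 (25500 nM) says little about such a change, as it keeps the chloro and adds another. The closer guide is compound 3 (3440 nM), where the chloro also leaves and an oxygen-bearing group enters. Among the measured compounds shown here, no measured compound carries a 3-hydroxyphenyl, so the match is loose. The expected step in this assay is a 4.6-fold lower number from compound 1 to compound 4 (0.66 log units; beyond the scatter) and points the same way as the methoxy step, somewhat smaller in size. For compound 4 the estimated value is 6000 nM with an expected range from 1800 nM to 20000 nM on this reading.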

Compound 4, half-maximal inhibitory concentration: 15700 nM
Compound 4: the middle estimate sits 2.6-fold (0.42 log units) below what was measured; the range from low to high includes it.
By their numbers in this assay, from the lowest: compound 3; then compounds 4, 2 and 1 (each within the scatter of the next).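

In this assay, 3-hydroxyphenyl in place of 2-chlorophenyl on a nitrogen on an aromatic ring leaves the number within the scatter (a 1.8-fold lower number from compound 1 to compound 4 (0.25 log units; within the scatter)), even though the chloro leaves and a hydrogen-bond donor enters. Losing the chloro and gaining an oxygen-bearing group is therefore not enough on its own to reproduce the methoxy step (an 8.0-fold lower number from compound 1 to compound 3 (0.90 log units; beyond the scatter)), which remains the only step in the series beyond the scatter. No measured property bears on this result, and the series offers no explanation for it.

The compounds shown leave open whether the gap between compound 4 at 15700 nM and compound 3 at 3440 nM follows from the group itself or from where it sits, since these two compounds differ in both the oxygen-bearing group and its place on the ring. A 3-methoxyphenyl and a 2-hydroxyphenyl would separate those two readings, and a 3-aminophenyl would show whether a nitrogen-bearing group in place of the hydroxy behaves any differently.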